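A few compounds are considered here, and "the series" means these few. Any claim that something is new, unique, unknown or untested is made for them only; others in the source may bear on it.

In a functional assay (trachea) with Cavia porcellus as the target (on this read-out lower numbers stand for an effect already at smaller amounts and higher numbers for an effect only at larger amounts of compound), compound 1 `CCCn1c(=O)n(CCO)c(=O)c2[nH]cnc21` gives 510 nM, compound 2 `CCCn1c(=O)n(CCOC)c(=O)c2[nH]cnc21` gives 700 nM and compound 3 `CCCn1c(=O)n(C)c(=O)c2[nH]cnc21` gives 1600 nM. Compound 3 therefore carries the highest number of the three, and both of the others lie beyond the scatter from it.

Compound 4 `CCCn1c(=O)n(C)c(=O)c2c1ncn2CCN(C)C` keeps the core of compound 3 and takes 2-(dimethylamino)ethyl in place of hydrogen on an aromatic nitrogen of the five-membered aromatic ring (2-(dimethylamino)ethyl in place of hydrogen on an aromatic nitrogen).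

Among the compounds with values here, no measured step touches that nitrogen, so the available steps offer only a rough guide to size. Those that remove the end of the chain on a different aromatic nitrogen were modest: a 3.1-fold higher number from compound 1 to compound 3 (0.50 log units; beyond the scatter) and a 2.3-fold higher number from compound 2 to compound 3 (0.36 log units; beyond the scatter). Capping the hydroxyl, a 1.4-fold higher number from compound 1 to compound 2 (0.14 log units; within the scatter), stayed within the scatter.

With a 3.1-fold higher number from compound 1 to compound 3 (0.50 log units; beyond the scatter) as the guide to size, a modest move toward a higher number is expected in this assay, although the data give no direct support for that direction. The estimated step runs a 2.5-fold higher number from compound 3 to compound 4 (0.40 log units; beyond the scatter). For compound 4 the estimated value is 4000 nM, with an expected range from 1000 nM to 16000 nM.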

Compound 4, half-maximal effective concentration: > 100000 nM
Compound 4: only a limit was reported (the forecaster's own chance of this, stated with the estimate: 10%); at least 25-fold (1.39 log units) between middle value and limit.
By their numbers in this assay, from the lowest: compounds 1 and 2 (each within the scatter of the next); then compound 3. At a limit, above all of these: compound 4.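

The change from hydrogen to 2-(dimethylamino)ethyl on an aromatic nitrogen of the five-membered aromatic ring gives an at least 62-fold higher number from compound 3 to compound 4 (1.79 log units; beyond the scatter) in this assay. Within the data shown here, this is the first large step, and it shows that this nitrogen, which no earlier step touched, can carry a change with a far bigger effect on the read-out than the modest step of a 3.1-fold higher number from compound 1 to compound 3 (0.50 log units; beyond the scatter) at the chain on the other aromatic nitrogen. Compound 4 is recorded only at a limit, so the step gives a minimum for the size of the change and not the size itself: the limit of > 100000 nM in this assay, at which 1 of the 4 values shown sits.

With a single substituent on this nitrogen, the compounds shown leave open whether the large step belongs to the dimethylamino end of the chain or to the presence of any chain at that place. A plain methyl, an ethyl chain ending in a hydroxyl, or a longer chain ending in a dimethylamino group on the same nitrogen would be needed to tell these readings apart.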